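Three Measured Analogues and One Untested Ether

The compounds below may be only part of what the source reports. "The series", "measured", "known", "first", "only" and "open" are said of these compounds alone.

Compound 1 `COc1ccc(F)cc1CNCCCNc1ccnc2cc(CCc3ccccc3)ccc12` gives 4240 nM in an ADME assay on HepG2 cells (Homo sapiens) for cytotoxicity, read by luminescence, CellTiter-Glo and ATP content, with a stated time of 72 h; on this read-out higher numbers stand for an effect only at larger amounts of compound and lower numbers for an effect already at smaller amounts.
Compound 2 `COc1ccc(F)cc1CNCCCNc1ccnc2cc(CC(C)C)ccc12` gives 2900 nM in this assay.
Compound 3 `COc1ccc(F)cc1CNCCCNc1ccnc2cc(-c3ccccc3)ccc12` gives 2960 nM in this assay.

Compound 3 sits second highest of the three numbers, yet the steps of a 1.0-fold higher number from compound 2 to compound 3 (0.01 log units; within the scatter) and a 1.4-fold lower number from compound 1 to compound 3 (0.16 log units; within the scatter) both stay within the scatter, so the three measured compounds cannot be told apart. Compound 4 `COc1ccc(F)cc1CNCCCNc1ccnc2cc(Oc3ccc(F)cc3)ccc12` is not yet measured. It differs from compound 3 by 4-fluorophenoxy in place of phenyl on an aromatic carbon. Among the measured compounds shown here, no measured step exchanges a ring for an ether-linked ring at this place; the nearest precedents, a 1.5-fold lower number from compound 1 to compound 2 (0.16 log units; within the scatter) and a 1.4-fold lower number from compound 1 to compound 3 (0.16 log units; within the scatter), were both small. Compound 4 is therefore expected to show a 1.1-fold higher number from compound 3 to compound 4 (0.05 log units; within the scatter), no step beyond the scatter. Compound 4 is estimated at 3300 nM, within 1500 nM to 7500 nM.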

Compound 4, half-maximal effective concentration: 6600 nM
Estimate against measurement, compound 4: 2.0-fold (0.30 log units) below, and the stated range covers the measured number.
By their numbers in this assay, from the lowest: compounds 2, 3, 1 and 4 (each within the scatter of the next, the first and the last beyond it).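

Among the compounds shown here, at this position, 4-fluorophenoxy in place of phenyl gives a 2.2-fold higher number from compound 3 to compound 4 (0.35 log units; beyond the scatter) in this assay and in place of isobutyl gives a 2.3-fold higher number from compound 2 to compound 4 (0.36 log units; beyond the scatter) as well, the first steps in this set beyond the scatter, though both are modest. In place of phenethyl it gives a 1.6-fold higher number from compound 1 to compound 4 (0.19 log units; within the scatter) and so does not set these two compounds apart. Nothing available here says why the ether-linked ring moves the number.

Plain phenoxy would separate the contribution of the oxygen link from that of the fluorine. An amine or a carboxylic acid at this position would show whether the number can move further.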